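The source may hold more compounds than are shown below. What is called first, only, known or untested is meant among the compounds shown, and "the series" means these compounds.

Measured so far:
compound 1, `Cn1cnc2c(Nc3ccccc3)ncnc21`, 6900 nM
compound 2, `c1ccc(-n2cnc3c(NC4CCCC4)ncnc32)cc1`, 8700 nM

In an assay on Cortex for binding affinity to adenosine receptor A1 (Rattus norvegicus), read by radioligand binding (a higher number here means a weaker inhibitor, a lower number a stronger inhibitor), compound 1 gives 6900 nM. In this assay compound 2 gives 8700 nM; the two numbers lie within the usual scatter of each other, so neither compound can be set apart from the other on these data.

Compound 3, `c1ccc(Nc2ncnc3c2ncn3-c2ccccc2)cc1`, has not yet been measured in this assay. It differs from compound 2 in one place: phenyl in place of cyclopentyl on a nitrogen on an aromatic ring. Among the compounds with values here, no step between two measured compounds shows what this change does, so the expectation rests on the two numbers alone, both of which are weak.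

Compound 3 is expected to keep a weak number, with a step of a 2.1-fold higher number from compound 2 to compound 3 (0.32 log units; beyond the scatter) toward a somewhat higher value, though a result inside the scatter would not surprise. The estimate for compound 3 is 18000 nM, with a range from 5000 nM to 70000 nM.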

Compound 3, inhibition constant: 6900 nM
Estimate against measurement, compound 3: 2.6-fold (0.42 log units) above; low and high end bracket the measured number.
By their numbers in this assay, from the lowest: compounds 1, 3 and 2 (each within the scatter of the next).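

In this assay, phenyl in place of cyclopentyl on a nitrogen on an aromatic ring gives a 1.3-fold lower number from compound 2 to compound 3 (0.10 log units; within the scatter), so cyclopentylamino and anilino cannot be told apart at this position. Phenyl in place of methyl on an aromatic nitrogen gives no change at the digits printed from compound 1 to compound 3 (within the scatter), so a second place now shows two quite different groups that the assay does not separate, and compound 3 links the two exchanges. Nothing available bears on why these numbers stay together.

All three compounds lie within the scatter of one another, so neither position has yet shown any group that moves the number. On these data alone, whether an amine, a carboxylic acid or a longer chain at either place would carry the number beyond the scatter, in either direction, stays open.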